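A few compounds are considered here, and "the series" means these few. Any claim that something is new, unique, unknown or untested is made for them only; others in the source may bear on it.

In a functional assay on HCT-116 cells (Homo sapiens) for inhibition, read by MTT assay, with a stated time of 72 h (a higher number here means a weaker inhibitor of growth, a lower number a stronger inhibitor of growth), compound 2 `Cn1ccc2cc(-c3cnccc3/C=C/C(=O)O)ccc21` gives 7260 nM and compound 3 `CNC(=O)/C=C/c1ccncc1-c1ccc2c(ccn2C)c1` gives 4450 nM. Within the data shown here, these are the only two numbers, and compound 2 stands level with compound 3. Compound 1 `O=C(/C=C/c1ccncc1-c1ccc2[nH]ccc2c1)N1CCOCC1`, which has hydrogen on the aromatic nitrogen, is recorded as "not determined" (no result reported). Compound 4 `O=C(O)/C=C/c1ccncc1-c1ccc2[nH]ccc2c1` departs from compound 2 by one change, (hydrogen in place of methyl on an aromatic nitrogen), hydrogen in place of methyl on an aromatic nitrogen. Among the measured compounds shown here, the only measured step, a 1.6-fold lower number from compound 2 to compound 3 (0.21 log units; within the scatter), concerns a carbonyl carbon and not this nitrogen, so no measurement bears directly on the change. No step beyond the scatter is therefore expected in this assay. The expected step is a 1.1-fold lower number from compound 2 to compound 4 (0.05 log units; within the scatter). For compound 4 the estimate is 6500 nM, with an expected range of 2800 nM to 16000 nM.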

Compound 4, concentration for 50% growth inhibition: > 30000 nM
Compound 4: a limit, no number; the forecaster's own chance of this, stated with the estimate: 10%; at least 4.6-fold (0.66 log units) between middle value and limit.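

Hydrogen in place of methyl on an aromatic nitrogen brings an at least 4.1-fold higher number from compound 2 to compound 4 (0.61 log units; beyond the scatter) in this assay. This is the first step shown at this position and the first beyond the scatter, as the only earlier step concerned a carbonyl carbon. The size of the step stays open, as compound 4 has only a limit and not a number: the limit of > 30000 nM in this assay, at which 1 of the 4 values shown sits.

As far as these compounds go, whether an ethyl group on this nitrogen would keep the value of compound 2 remains open. So does whether the same change gives a similar step when a methylamino group replaces the hydroxy on the carbonyl carbon.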